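Chloroacetyl Urea in Place of the Allyl Carbamate

The source may report more compounds than this note shows. Statements on the series, on what has been measured and on what is new or still open speak of the compounds shown alone.

Measured so far in a functional assay on A549 cells (Homo sapiens) for antiproliferative activity, read by MTT assay; on this read-out lower numbers stand for stronger inhibition and higher numbers for weaker inhibition:
Compound 1 `COC(=O)N1CCCc2cc(S(=O)(=O)N3CC(c4ccccc4)NC3=O)ccc21` gives 1150 nM.
Compound 2 `CCCCOC(=O)N1CCCc2cc(S(=O)(=O)N3CC(c4ccccc4)NC3=O)ccc21` gives > 20000 nM, which is a limit of the assay and not a number.
Compound 3 `C=CCOC(=O)N1CCCc2cc(S(=O)(=O)N3CC(c4ccccc4)NC3=O)ccc21` gives 4310 nM.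

Compound 3 gives the higher of the two numbers, and a 3.7-fold higher number from compound 1 to compound 3 (0.57 log units; beyond the scatter) separates it from the lower one.

Compound 4 `O=C(CCl)NC(=O)N1CCCc2cc(S(=O)(=O)N3CC(c4ccccc4)NC3=O)ccc21` differs from compound 3 by ((chloromethyl)carbonyl)amino in place of allyloxy on a carbonyl carbon. The measured steps all vary the chain on the oxygen of the carbamate: an at least 17-fold higher number from compound 1 to compound 2 (1.24 log units; beyond the scatter), a 3.7-fold higher number from compound 1 to compound 3 (0.57 log units; beyond the scatter) and an at least 4.6-fold lower number from compound 2 to compound 3 (0.66 log units; beyond the scatter). None of them swaps the oxygen itself for a nitrogen, so they bear only loosely on this change; the two groups are of similar size. No step beyond the scatter is therefore expected, meaning a 1.2-fold lower number from compound 3 to compound 4 (0.09 log units; within the scatter). Compound 4 is estimated at 3500 nM, between 600 nM and 20000 nM.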

Compound 4, half-maximal inhibitory concentration: 449 nM
The estimate for compound 4 lay 7.8-fold (0.89 log units) above the measured number; the whole stated range lies above it.
By their numbers in this assay, from the lowest: compound 4; then compound 1; then compound 3. At a limit, above all of these: compound 2.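

Every earlier change kept the oxygen on the carbonyl carbon, and none gave a number lower than that of compound 1. Putting ((chloromethyl)carbonyl)amino in place of allyloxy gives a 9.6-fold lower number from compound 3 to compound 4 (0.98 log units; beyond the scatter), and the same group in place of methoxy gives a 2.6-fold lower number from compound 1 to compound 4 (0.41 log units; beyond the scatter), so this position accepts more than a carbamate and here reaches the lowest number of the set. Compound 2 sits at a limit of the assay, not a number, and its step reads an at least 44-fold lower number from compound 2 to compound 4 (1.64 log units; beyond the scatter).

Going by these compounds, whether the gain depends on the chlorine or on the amide hydrogen stays open. A plain acetylamino group in the same place would separate the two.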